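This account rests on a few compounds, and the source may have more. Where it says the series, first, only, none or still open, it means among the compounds named here.

In an ADME assay on HepG2 cells (Homo sapiens) for cytotoxicity (a higher number here means that more compound is needed for the effect, a lower number that less compound is needed), three compounds built on a shared core have been measured, and none gives a number. Compound 1 `Cc1ccc(S(=O)(=O)N[C@@H](CC(=O)NC(C)(C)C)C(=O)NCCNC(=O)c2cc(Cl)ccn2)cc1` gives only a limit, > 11000 nM. Compound 2 `Cc1ccc(S(=O)(=O)N[C@@H](CC(=O)NC(C)(C)C)C(=O)NCCNC(=O)c2cccc(O)c2)cc1` also gives only a limit, > 11000 nM. Compound 3 `Cc1ccc(S(=O)(=O)N[C@@H](CC(=O)NC(C)(C)C)C(=O)NCCNC(=O)c2cccc(C(C)C)c2)cc1` gives a limit as well, > 11000 nM, so it stands level with the other two values as far as they can be read.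

The next compound, compound 4 `Cc1ccc(S(=O)(=O)N[C@@H](CC(=O)NC(C)(C)C)C(=O)NCCNC(=O)c2ccccc2F)cc1`, carries 2-fluorophenyl in place of 3-isopropylphenyl on a carbonyl carbon. Among the measured compounds shown here, three measured steps bear on this change: a step that the two limits leave unreadable from compound 1 to compound 2, a step that the two limits leave unreadable from compound 1 to compound 3 and a step that the two limits leave unreadable from compound 2 to compound 3. None of them has a readable size, and none gives a direction. For the measured compounds named here, the one guide is the limit of > 11000 nM in this assay, at which 3 of the 3 values shown sit, so compound 4 is expected to remain at that limit, with no step beyond the scatter. The expected change is a step that the limit leaves unreadable from compound 3 to compound 4. The estimate for compound 4 is 15000 nM, with an expected range from 9000 nM to 30000 nM.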

Compound 4, half-maximal effective concentration: > 11000 nM
Compound 4: no number, only a limit (the forecaster's own chance of this, stated with the estimate: 90%); the middle value lies beyond the limit too.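

Compound 4 also gives only a limit, and its steps to compound 1, compound 2 and compound 3 cannot be read, in size or in direction. The compounds shown leave open whether changing the group on the carbonyl carbon alters the half-maximal effective concentration at all.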